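The compounds below may be only part of what the source reports. "The series", "measured", "known", "first", "only" and "open" are said of these compounds alone.

In a functional assay (aorta) with Rattus norvegicus as the target (on this read-out lower numbers stand for an effect already at smaller amounts and higher numbers for an effect only at larger amounts of compound), compound 1 `C/N=C(/S)C1=CC(C)(C(F)(F)F)Oc2ccc([N+](=O)[O-])cc21` gives 0.302 nM and compound 2 `CC1(C)C=C(/C(S)=N\CCC#N)c2cc([N+](=O)[O-])ccc2O1` gives 0.372 nM so the two values lie within the usual scatter of each other. Within the data shown here, compound 3 `CC1(C(F)(F)F)C=C(/C(S)=N\CCC#N)c2cc([N+](=O)[O-])ccc2O1` differs from compound 2 by trifluoromethyl in place of methyl on a saturated ring carbon and no pair of measured compounds shows this step on its own. No step beyond the scatter is therefore expected in this assay and no direction can be foreseen. For compound 3 the estimated value is 0.35 nM with an expected range from 0.1 nM to 1.2 nM in this estimate. The estimate means an expected 1.1-fold lower number from compound 2 to compound 3 (0.03 log units; within the scatter) within the scatter.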

Compound 3, half-maximal effective concentration: 0.363 nM
Beside the measured number, compound 3's estimate is 1.0-fold (0.02 log units) below it; the range from low to high includes it.
By their numbers in this assay, from the lowest: compounds 1, 3 and 2 (each within the scatter of the next).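

In this assay, trifluoromethyl in place of methyl on the saturated ring carbon next to the ring oxygen, now seen on its own, gives a 1.0-fold lower number from compound 2 to compound 3 (0.01 log units; within the scatter), so this exchange leaves no readable step at this position. Cyanomethyl in place of hydrogen on the saturated chain carbon bound to a double-bonded nitrogen gives a 1.2-fold higher number from compound 1 to compound 3 (0.08 log units; within the scatter), which also leaves no readable step. Nothing available explains either result. From the compounds shown here alone, it remains open how an amine or a hydroxymethyl on that ring carbon would read, and how a longer chain in place of cyanomethyl would.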